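Trimming a Hydroxyphenyl to Hydroxy on a Polyphenol Core

The compounds below may be only part of what the source reports. "The series", "measured", "known", "first", "only" and "open" are said of these compounds alone.

Compound 1, `CC1(C)OC(=O)C2(C(=O)O1)[C@@H](c1ccc(-c3ccc(O)cc3)cc1)CC(=O)C[C@H]2c1ccccc1`, gives 9000 nM in a functional assay on K562 cells (Homo sapiens) for antiproliferative activity, read by trypan blue exclusion, with a stated time of 48 h; a higher number here means a weaker inhibitor, a lower number a stronger inhibitor.
Compound 2, `CC1(C)OC(=O)C2(C(=O)O1)[C@@H](c1ccc(-c3ccc(-c4ccc(O)cc4)cc3)cc1)CC(=O)C[C@H]2c1ccccc1`, gives 8000 nM in this assay.
Compound 3, `Oc1ccc(-c2ccc(-c3cc(O)cc(O)c3)cc2)cc1`, gives 20000 nM in this assay.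

Compound 3 gives the highest number of the three, and its gaps to compound 1 and compound 2 both lie beyond the scatter. How the core of compound 3 differs from that of compound 2 is not broken down here.

Compound 4, `Oc1ccc(-c2cc(O)cc(O)c2)cc1`, is not yet measured. It differs from compound 3 by hydroxy in place of 4-hydroxyphenyl on an aromatic carbon. The same kind of change is seen between compound 2 and compound 1, where it is hydroxy in place of 4-hydroxyphenyl on an aromatic carbon; there the place is para to a large group, whereas in compound 3 it is para to a group of 8 heavy atoms, so the two changes are of the same kind but not the same. That earlier step measured a 1.1-fold higher number from compound 2 to compound 1 (0.05 log units; within the scatter).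

Because the earlier change gave a 1.1-fold higher number from compound 2 to compound 1 (0.05 log units; within the scatter), the step expected in this assay is small, about a 1.1-fold higher number from compound 3 to compound 4 (0.04 log units; within the scatter). Compound 4 is thus estimated at 22000 nM, most likely between 10000 nM and 45000 nM.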

Compound 4, half-maximal inhibitory concentration: > 80000 nM
Compound 4: a limit, no number (the forecaster's own chance of this, stated with the estimate: 25%); middle value at least 3.6-fold (0.56 log units) away from the limit.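

Cutting the 4-hydroxyphenyl down to hydroxy matters on this core: in this assay the change gives an at least 4.0-fold higher number from compound 3 to compound 4 (0.60 log units; beyond the scatter). On these data alone, the result therefore shows that the change does not carry over with the same effect from the core of compound 2 to the core of compound 3: the same change on two cores in this assay, a 1.1-fold higher number (0.05 log units; within the scatter) from compound 2 to compound 1 and an at least 4.0-fold higher number (0.60 log units; beyond the scatter) from compound 3 to compound 4, at least 3.5-fold (0.55 log units) apart, beyond the scatter of two such steps Compound 4 gives > 80000 nM, which is a limit of the assay and not a number, so the full size of this step stays unknown, and two cores do not show which feature of a core sets the size of the step.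

The compounds shown leave open how the same place responds to other groups, such as an amine or a carboxylic acid, in place of the hydroxy or the 4-hydroxyphenyl. They also leave open whether the same change on a further core would give a small step, as on the core of compound 2, or a large one, as on the core of compound 3.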